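The compounds below may be only part of what the source reports. "The series", "measured", "known", "first", "only" and "open" are said of these compounds alone.

In an ADME assay on MRC5 cells (Homo sapiens), read by MTT assay, with a stated time of 72 h (on this read-out lower numbers stand for stronger inhibition and higher numbers for weaker inhibition), three compounds sharing one core have been tested. Compound 1 `CNc1ncnc2c1c(-c1ccccc1)cn2[C@@H]1O[C@H](CO)[C@@H](O)[C@H]1O` gives > 100000 nM, which is a limit of the assay and not a number. Compound 3 `C#Cc1cn([C@@H]2O[C@H](CO)[C@@H](O)[C@H]2O)c2ncnc(NC)c12` gives > 100000 nM, again a limit. Among the measured compounds shown here, compound 2 `CNc1ncnc2c1c(-c1cc3ccccc3o1)cn2[C@@H]1O[C@H](CO)[C@@H](O)[C@H]1O` gives 75300 nM, the only actual number in the set. The others stand at the limit of > 100000 nM in this assay, at which 2 of the 3 values shown sit.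

Compound 4 `CN(C)c1ncnc2c1c(-c1cc3ccccc3o1)cn2[C@@H]1O[C@H](CO)[C@@H](O)[C@H]1O` departs from compound 2 by methyl in place of hydrogen on a nitrogen on an aromatic ring, turning methylamino to dimethylamino. For the measured compounds named here, no measured step touches this nitrogen. The three that exist all fall on an aromatic carbon: an at least 1.3-fold lower number from compound 1 to compound 2 (0.12 log units; that floor lies within the scatter) and an at least 1.3-fold higher number from compound 2 to compound 3 (0.12 log units; that floor lies within the scatter) and a step that the two limits leave unreadable from compound 1 to compound 3. None of them can be read as a change beyond the scatter, so they give only weak guidance. The expected result is no change beyond the scatter, with the estimated step being a 1.1-fold higher number from compound 2 to compound 4 (0.05 log units; within the scatter). A reading at the limit of the assay would not be surprising. For compound 4 the estimated value is 85000 nM, with an expected range of 40000 nM to 150000 nM.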

Compound 4, half-maximal inhibitory concentration: > 100000 nM
Compound 4: a limit, no number; the forecaster's own chance of this, stated with the estimate: 45%; middle value at least 1.1-fold (0.07 log units) away from the limit.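

Among the compounds shown here, this is the first change in the set at the nitrogen on the aromatic ring, as all earlier steps fell on an aromatic carbon. In this assay, methyl in place of hydrogen at this nitrogen, turning methylamino to dimethylamino, gives an at least 1.3-fold higher number from compound 2 to compound 4 (0.12 log units; that floor lies within the scatter), so the data show no change beyond the scatter, although the true size of the step could be larger. Compound 4 gives > 100000 nM, which is a limit of the assay and not a number, and the set now gathers at that limit: the limit of > 100000 nM in this assay, at which 3 of the 4 values shown sit.

On these data alone, whether a free amine or a longer chain such as ethylamino at this nitrogen would give a readable step remains open. Also open, as far as these compounds go, is whether dimethylamino would behave the same way with phenyl or ethynyl on the aromatic carbon in place of 1-benzofuran-2-yl.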